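Bromo to trifluoromethyl on the benzylic ring of an isatin-like series

This account rests on a few compounds, and the source may have more. Where it says the series, first, only, none or still open, it means among the compounds named here.

Two compounds of this series have numbers in a functional assay on CHO cells for positive allosteric modulation of muscarinic acetylcholine receptor M5 (Homo sapiens), read by calcium flux; a higher number here means that more compound is needed for the effect, a lower number that less compound is needed. Compound 1 `O=C1C(=O)N(Cc2ccc(Br)cc2)c2c(F)cccc21` gives 1930 nM in this assay. Compound 2 `COc1cccc(CN2C(=O)C(=O)c3cc(OC(F)(F)F)ccc32)c1` gives 1700 nM in this assay. Only these two numbers exist, and the gap between compound 1 and compound 2 lies within the scatter, so neither can be set apart from the other on the numbers at hand.

Compound 3 `O=C1C(=O)N(Cc2ccc(C(F)(F)F)cc2)c2c(F)cccc21` is not yet measured. It differs from compound 1 by trifluoromethyl in place of bromo on an aromatic carbon. Among the measured compounds shown here, no measured pair shows what such an exchange does, so there is no step to lean on. For compound 3 the expected step of a 1.0-fold higher number from compound 1 to compound 3 (0.02 log units; within the scatter) is none beyond the scatter, in either direction. The estimate for compound 3 in this assay is 2000 nM, with a range from 700 nM to 6000 nM.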

Compound 3, half-maximal effective concentration: 3260 nM
The estimate for compound 3 lay 1.6-fold (0.21 log units) below the measured number; low and high end bracket the measured number.
By their numbers in this assay, from the lowest: compounds 2, 1 and 3 (each within the scatter of the next).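

In this assay, among the compounds shown here, the first direct look at this position shows that trifluoromethyl in place of bromo, on an aromatic carbon para to a large group, gives a 1.7-fold higher number from compound 1 to compound 3 (0.23 log units; within the scatter). For the compounds shown here, the exchange adds heavy atoms but no ring, hydrogen-bond donor, hydrogen-bond acceptor or net charge, and this single pair shows no step that can be told from the scatter. No measurement available here offers an explanation for this result.

As far as these compounds go, whether this position tolerates every replacement remains open, since a nitrile, an amine or a carboxylic acid in the same place could behave differently. From the compounds shown here alone, it also remains open whether the same exchange gives a similar step on a different core, since a single pair cannot show that.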